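A few compounds are considered here, and "the series" means these few. Any claim that something is new, unique, unknown or untested is made for them only; others in the source may bear on it.

Working notes on the guanylhydrazone series.

Compound 1 `N=C(N)N/N=C/c1c(-c2ccsc2)nc2sccn12` is the reference point. In a functional assay on cells (Cancer cell lines, Homo sapiens) for inhibition (a lower number here means a stronger inhibitor of growth, a higher number a weaker inhibitor of growth), compound 1 gives 15100 nM. Compound 2 `Cc1cc(-c2nc3sccn3c2/C=N/NC(=N)N)c(C)s1` carries the change 2,5-dimethylthiophen-3-yl in place of thiophen-3-yl on an aromatic carbon and gives 16600 nM in this assay. The step of a 1.1-fold higher number from compound 1 to compound 2 (0.04 log units; within the scatter) shows the change of this size has no resolved effect on the growth-inhibition read-out on this core.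

Compound 3 `N=C(N)N/N=C/c1c(-c2ccsc2)nc2n1CCS2` has a different core; the difference between the core of compound 1 and the core of compound 3 is not broken down here. In this assay compound 3 gives 28800 nM; against compound 1 and compound 2 this number stands within the scatter of both, so no ordering among the three is claimed.

Compound 4 `Cc1cc(-c2nc3n(c2/C=N/NC(=N)N)CCS3)c(C)s1` is not yet measured. It differs from compound 3 by 2,5-dimethylthiophen-3-yl in place of thiophen-3-yl on an aromatic carbon. The place is the same kind of place as in the step from compound 1 to compound 2, but not the same word for word: in compound 4 it is also two ring bonds from two ring atoms that each bear a fused ring, so this is the same kind of change rather than the same change.

Within the data shown here, the expectation for compound 4 rests on the only precedent, the step of a 1.1-fold higher number from compound 1 to compound 2 (0.04 log units; within the scatter), which was within the scatter. The step from compound 3 to compound 4 is therefore estimated as a 1.0-fold higher number from compound 3 to compound 4 (0.02 log units; within the scatter), a near-neutral change. Compound 4 is expected to give about 30000 nM in this assay, with a range of roughly 15000 nM to 60000 nM allowing for the scatter and the difference in core. Compound 3 sits at the high end of the series, and the measurement will show whether the weak trend holds.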

Compound 4, concentration for 50% growth inhibition: 17000 nM
The estimate for compound 4 lay 1.8-fold (0.25 log units) above the measured number; the range from low to high includes it.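

In this assay, placing 2,5-dimethylthiophen-3-yl in place of thiophen-3-yl on the core of compound 3 gives a 1.7-fold lower number from compound 3 to compound 4 (0.23 log units; within the scatter), so the change has no resolved effect on growth inhibition on this core. Set beside the earlier step, the change carries from one core to the other with no resolved difference between the two steps: the same change on two cores in this assay, a 1.1-fold higher number (0.04 log units; within the scatter) from compound 1 to compound 2 and a 1.7-fold lower number (0.23 log units; within the scatter) from compound 3 to compound 4, 1.9-fold (0.27 log units) apart, within the scatter of two such steps. This shows agreement within the scatter on two cores only, with all four compounds in the same range of values; it does not show that the change would be neutral on any other core, and the two steps pointing in opposite directions cannot be read as an effect of the core.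

The compounds shown hold only thiophen-3-yl and 2,5-dimethylthiophen-3-yl at this place, so it remains open whether a group of another kind there, such as an amine, a carboxylic acid or a longer alkyl chain, would move the growth-inhibition number beyond the scatter on either core. Going by these compounds, the guanylhydrazone chain is also common to all four compounds, so what an amide at that place would do remains open as well.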